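Swapping trifluoromethyl for an oxadiazole on an aryl amide

This account rests on a few compounds, and the source may have more. Where it says the series, first, only, none or still open, it means among the compounds named here.

Measured so far:
- compound 1, `C[C@@H](Nc1nccc(Cl)c1NC(=O)CC#N)c1ccc(-c2cccc(F)c2C(F)(F)F)cc1`, 52%
- compound 2, `COC(=O)c1c(Cl)cccc1-c1ccc([C@@H](C)Nc2nccc(Cl)c2NC(=O)CC#N)cc1`, 43%
- compound 3, `COC(=O)c1ccc(Cl)cc1-c1ccc([C@@H](C)Nc2nccc(Cl)c2NC(=O)CC#N)cc1`, 6%

In an in vivo ADME assay on the whole organism (strain Sprague-Dawley) for pharmacokinetics, with Rattus norvegicus as the target, at a dose of 10 mg/kg by the oral route (a higher number here means that a larger share of the oral dose reaches the circulation, a lower number that a smaller share of the oral dose reaches the circulation), compound 1 gives the highest of the three numbers. Compound 2 sits close to it, a number 9 percentage points lower from compound 1 to compound 2 (within the scatter), whereas compound 3 falls far behind, a number 46 percentage points lower from compound 1 to compound 3 (beyond the scatter), and the two ester-bearing compounds differ from one another as well, a number 37 percentage points lower from compound 2 to compound 3 (beyond the scatter). Compound 4, `Cc1nc(-c2c(F)cccc2-c2ccc([C@@H](C)Nc3nccc(Cl)c3NC(=O)CC#N)cc2)no1`, keeps the core of compound 1 and its fluoro group and changes only one substituent: 5-methyl-1,2,4-oxadiazol-3-yl in place of trifluoromethyl on an aromatic carbon.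

Going by the values given here, no measured step swaps a trifluoromethyl for a heteroaromatic ring, so nothing bears on this change directly. The three measured steps show only that altering this outer aryl can leave the number where it is or lower it considerably, and never raised it. The step from compound 1 to compound 4 is therefore expected to go down, by a moderate amount, a number 22 percentage points lower from compound 1 to compound 4 (beyond the scatter). Compound 4 is estimated at 30%, within a range from 8% to 55%.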

Compound 4, oral bioavailability: 50%
For compound 4 the middle estimate is 20 percentage points below the measured one, and the stated range covers the measured number.
By their numbers in this assay, from the lowest: compound 3; then compounds 2, 4 and 1 (each within the scatter of the next).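

In this assay, putting 5-methyl-1,2,4-oxadiazol-3-yl in place of trifluoromethyl gives a number 2 percentage points lower from compound 1 to compound 4 (within the scatter). Going by these compounds alone, this aromatic carbon, ortho to a fluoro group, therefore accepts a five-membered aromatic ring with 3 hetero atoms and 3 hydrogen-bond acceptors in place of a group with no ring and no acceptors, without a shift beyond the scatter, something no earlier step could show. The data at hand offer no measurement that explains why the number holds.

Going by these compounds, it remains open whether this tolerance is specific to the 5-methyl-1,2,4-oxadiazol-3-yl group or extends to quite different groups on the same carbon, such as an amine or a carboxylic acid. Also open, on these data alone, is whether the methyl on the oxadiazole could give way to a longer chain with the same outcome.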